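The source may report more compounds than this note shows. Statements on the series, on what has been measured and on what is new or still open speak of the compounds shown alone.

The question here is what happens to cell killing when one small piece of compound 3 `CCOc1ccc(NC(=O)C(=O)c2cn(C(C)C)c3ccccc23)cn1` is trimmed. In a functional assay on FaDu cells (Homo sapiens) for cytotoxicity, read by MTT assay, with a stated time of 72 h (on this read-out higher numbers stand for lower toxicity in this test and lower numbers for higher toxicity in this test), compound 3 gives 175 nM. Compound 2 `COc1ccc(NC(=O)C(=O)c2cn(C(C)C)c3ncccc23)cn1` gives 126 nM in the same test. These two numbers lie within the usual scatter of repeated measurements, so they cannot be told apart. Compound 1 `COCCn1cc(C(=O)C(=O)Nc2ccc(OCC(=O)O)nc2)c2ccccc21` is different, since it yields no number in this assay. Its result of > 10000 nM is only a limit of the assay.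

Compound 4 `COc1ccc(NC(=O)C(=O)c2cn(C(C)C)c3ccccc23)cn1` has not yet been measured. It is compound 3 with hydrogen in place of methyl on a saturated chain carbon bound to an oxygen on an aromatic ring, which turns ethoxy into methoxy (hydrogen in place of methyl on a saturated chain carbon bound to an oxygen on an aromatic ring). The shared core and the rest of the molecule stay the same. Among the measured compounds shown here, no measured pair of compounds shows what this exact change does, so the expectation has to start from compound 3 at 175 nM. For so small a change, no shift beyond the scatter is expected. The expected 1.2-fold lower number from compound 3 to compound 4 (0.07 log units; within the scatter) is therefore slight. For compound 4, the estimated value is 150 nM, with an expected range of 60 nM to 400 nM.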

Compound 4, concentration lethal to 50% of the cells: 85 nM
Compound 4: the middle estimate sits 1.8-fold (0.25 log units) above what was measured, within the range that was stated.
By their numbers in this assay, from the lowest: compounds 4, 2 and 3 (each within the scatter of the next, the first and the last beyond it). At a limit, above all of these: compound 1.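

Trimming ethoxy to methoxy, on a saturated chain carbon bound to an oxygen on an aromatic ring, is the first change here that can be read on its own: in this assay there is a 2.1-fold lower number from compound 3 to compound 4 (0.31 log units; beyond the scatter), with the shared core and the rest of the molecule unchanged. This end of the molecule therefore has a visible link to the read-out, as losing a single methyl goes with a lower number, which stands for higher toxicity in this test, although the step only just clears the usual scatter. Nothing among the data given explains why the shorter chain goes with the lower number.

As far as these compounds go, only ethoxy and methoxy can be compared at this place, so it remains open how a longer chain such as propoxy, a hydroxyl group or an amine would read in the same test. This single pair also leaves open whether trimming ethoxy to methoxy would give a step of similar size on a different core.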